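From 4-chlorophenyl to 4-bromophenyl: working notes

A few compounds are considered here, and "the series" means these few. Any claim that something is new, unique, unknown or untested is made for them only; others in the source may bear on it.

In a functional assay on M21 cells (Homo sapiens) for antiproliferative activity, read by sulforhodamine B assay, with a stated time of 48 h (on this read-out higher numbers stand for weaker inhibition and lower numbers for stronger inhibition), compound 3 `O=C1NCCN1c1ccc(S(=O)(=O)Nc2ccc(Cl)cc2)cc1` gives 90 nM as the lowest of three numbers, against compound 1 `O=C1NCCN1c1ccc(S(=O)(=O)Nc2ccc(F)cc2)cc1` at 230 nM and compound 2 `CCCCc1ccc(NS(=O)(=O)c2ccc(N3CCNC3=O)cc2)cc1` at 450 nM on the same read-out. Compound 4 `O=C1NCCN1c1ccc(S(=O)(=O)Nc2ccc(Br)cc2)cc1` differs from compound 3 by bromo in place of chloro on an aromatic carbon with bromo in place of chloro on an aromatic carbon, para to a large group. Among the compounds with values here, the nearest precedent, chloro in place of fluoro, gave a 2.6-fold lower number from compound 1 to compound 3 (0.41 log units; beyond the scatter) as a modest step. Chloro in place of butyl gave a 5.0-fold lower number from compound 2 to compound 3 (0.70 log units; beyond the scatter) and butyl in place of fluoro gave a 2.0-fold higher number from compound 1 to compound 2 (0.29 log units; within the scatter) at the same position. Within the data shown here, no measured step exchanges chloro for bromo, so no step beyond the scatter is expected in this assay and no direction is favoured. The expected change is a 1.1-fold lower number from compound 3 to compound 4 (0.05 log units; within the scatter) on this estimate. Compound 4 is estimated at 80 nM with an expected range from 35 nM to 180 nM on this read-out.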

Compound 4, half-maximal inhibitory concentration: 130 nM
Compound 4: middle estimate off by 1.6-fold (0.21 log units), on the low side; measured number inside the range.
By their numbers in this assay, from the lowest: compounds 3, 4, 1 and 2 (each within the scatter of the next, the first and the last beyond it).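

At this position in this assay, bromo and chloro cannot be told apart (a 1.4-fold higher number from compound 3 to compound 4 (0.16 log units; within the scatter)). Bromo also stays within the scatter of fluoro (a 1.8-fold lower number from compound 1 to compound 4 (0.25 log units; within the scatter)), although chloro and fluoro differ beyond it, so bromo does not separate cleanly from either halogen. Only the change from butyl to bromo goes beyond the scatter (a 3.5-fold lower number from compound 2 to compound 4 (0.54 log units; beyond the scatter)).

No measurement shown accounts for these steps. Still open, going by these compounds, is how a methoxy, an amine, a carboxylic acid or a chain longer than butyl would read at this position.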